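Same Kind of Swap on a Second Core: Compound 4

The compounds below may be only part of what the source reports. "The series", "measured", "known", "first", "only" and "open" are said of these compounds alone.

Compound 1 `COc1ccc(C2CC(c3cccc4ccccc34)=NN2C(C)=O)cc1` and compound 2 `CC(=O)N1N=C(c2cccc3ccccc23)CC1/C=C/c1ccccc1` share a core and differ in one place, namely (2-phenylethenyl in place of 4-methoxyphenyl on a saturated ring carbon). In a functional assay on PC-3 cells (Homo sapiens) for cytotoxicity, read by sulforhodamine B assay, with a stated time of 48 h (on this read-out lower numbers stand for stronger inhibition and higher numbers for weaker inhibition), compound 1 gives 4930 nM, while compound 2 gives 21100 nM, so the step is a 4.3-fold higher number from compound 1 to compound 2 (0.63 log units; beyond the scatter). Compound 3 `COc1ccc(C2CC(c3ccc4ccccc4c3)=NN2CC=O)cc1` is built on a second core; how that core differs from the core of compound 1 is not broken down here. In this assay compound 3 gives 4530 nM, a number within the scatter of compound 1. Compound 4 `O=CCN1N=C(c2ccc3ccccc3c2)CC1/C=C/c1ccccc1` carries the same kind of change on this second core, (2-phenylethenyl in place of 4-methoxyphenyl on a saturated ring carbon). The surroundings are not identical: in compound 1 the altered carbon is next to the ring atom that bears an acetyl group, in compound 3 next to the ring atom that bears a formylmethyl group.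

Because a 4.3-fold higher number from compound 1 to compound 2 (0.63 log units; beyond the scatter) was modest and beyond the scatter, the author expects a comparable step of a 4.3-fold higher number from compound 3 to compound 4 (0.63 log units; beyond the scatter). Compound 4 is therefore estimated at 19500 nM in this assay. The expected range for compound 4 runs from 8000 nM to 45000 nM.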

Compound 4, half-maximal inhibitory concentration: 19100 nM
The estimate for compound 4 lay 1.0-fold (0.01 log units) above the measured number; low and high end bracket the measured number.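

In this assay, putting 2-phenylethenyl in place of 4-methoxyphenyl on the second core gives a 4.2-fold higher number from compound 3 to compound 4 (0.62 log units; beyond the scatter), a modest step. Set beside the step on the first core, the change carries over from one core to the other with no difference that can be told apart: the same change on two cores in this assay, a 4.3-fold higher number (0.63 log units; beyond the scatter) from compound 1 to compound 2 and a 4.2-fold higher number (0.62 log units; beyond the scatter) from compound 3 to compound 4, 1.0-fold (0.01 log units) apart, within the scatter of two such steps. Going by these compounds alone, still, this rests on only two pairs in a single assay; it does not show that the step would keep its size on any further core, and it does not explain why the change has this effect on either core.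

The compounds shown leave open whether a saturated chain such as 2-phenylethyl, or a ring bearing an amine or a carboxylic acid, would give a comparable step on the saturated ring carbon. They also leave open whether the step would persist if the ring atom that bears the acetyl or formylmethyl group carried a longer chain instead.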